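The source may report more compounds than this note shows. Statements on the series, on what has been measured and on what is new or still open speak of the compounds shown alone.

Measured compounds:
- compound 1 `CCn1c(/C=C2\SC(=O)N(CC(=O)N3CCCCC3)C2=O)nc2ccccc21`: in a functional assay on PC-3 cells (Homo sapiens) for inhibition, read by MTT assay, with a stated time of 48 h (a lower number here means a stronger inhibitor, a higher number a weaker inhibitor), compound 1 gives > 50000 nM
- compound 2 `Cn1c(/C=C2\SC(=O)N(CC(=O)Nc3nc(-c4ccccc4)cs3)C2=O)nc2ccccc21`: in this assay compound 2 gives 39900 nM
- compound 3 `CCn1c(/C=C2\SC(=O)N(CC(=O)N3CCc4cc(OC)c(OC)cc4C3)C2=O)nc2ccccc21`: in this assay compound 3 gives 33500 nM

All three compounds share the same core and differ only in the amide attached to the carbonyl on the methyl arm. The value of compound 1 is not a number but a limit of the assay; compound 1 sits at the limit of > 50000 nM in this assay, at which 1 of the 3 values shown sits, so its true value is not known, only that it lies beyond what this assay could measure. Compound 2 and compound 3 give numbers, and those two numbers lie within the usual scatter of each other, so nothing separates them.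

Compound 4 `CCn1c(/C=C2\SC(=O)N(CC(=O)N3CCOCC3)C2=O)nc2ccccc21` is not yet measured. It differs from compound 1 by morpholin-4-yl in place of piperidin-1-yl on a carbonyl carbon. Among the measured compounds shown here, since compound 1 stands only at a limit, no measured step is available to guide the size of this change. For the measured compounds named here, with every value so far weak or at the limit, the expectation is that compound 4 will also be weak, and the expected step of a number no higher from compound 1 to compound 4 (the limit leaves the size open) is none beyond the scatter. Compound 4 is therefore estimated at 50000 nM in this assay, with a range from 25000 nM to 100000 nM, and a good chance that only a limit is reported again.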

Compound 4, half-maximal inhibitory concentration: > 50000 nM
Compound 4: no number, only a limit; the forecaster's own chance of this, stated with the estimate: 60%; the middle value lies on the limit itself.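

In this assay compound 4, like compound 1, gives only a limit and not a number, so no step can be read between these two compounds: the limit of > 50000 nM in this assay, at which 2 of the 4 values shown sit. The compounds shown leave open whether morpholin-4-yl and piperidin-1-yl on this carbonyl carbon give different values at all.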